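Thioether oxadiazoles: methoxybenzyl capping of the phenol

The compounds below may be only part of what the source reports. "The series", "measured", "known", "first", "only" and "open" are said of these compounds alone.

Measured so far:
compound 1 `COc1cc(-c2nnc(SCc3ccccc3Br)o2)ccc1O` 17800 nM
compound 2 `COc1cccc(CSc2nnc(-c3ccc(O)c(OC)c3)o2)c1` 7410 nM

Within the data shown here, in a functional assay on cells (T-cell, Mus musculus, strain BALB/c) for inhibition, read by MTT assay, with stated times of 24 h and 72 h (a higher number here means a weaker inhibitor, a lower number a stronger inhibitor), compound 2 gives the lowest of the two numbers recorded; the only neighbour is compound 1, and the step of a 2.4-fold lower number from compound 1 to compound 2 (0.38 log units; beyond the scatter) places compound 2 beyond the scatter of compound 1.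

Compound 3 `COc1cccc(COc2ccc(-c3nnc(SCc4cccc(OC)c4)o3)cc2OC)c1` is not yet measured. It differs from compound 2 at one place: 3-methoxybenzyl in place of hydrogen on an oxygen on an aromatic ring

Among the measured compounds shown here, no measured step bears on this position. For the measured compounds named here, the single step so far, a 2.4-fold lower number from compound 1 to compound 2 (0.38 log units; beyond the scatter), concerns the group on the saturated chain carbon bound to sulfur, not the oxygen on the aromatic ring where compound 3 changes. Nothing in the series therefore tells how this assay answers to the hydroxy becoming (3-methoxybenzyl)oxy, and the expectation rests on the value of compound 2 alone.

With no guide from the data, the step of a 1.1-fold higher number from compound 2 to compound 3 (0.03 log units; within the scatter) is expected to stay near zero, with a wide band around it. Compound 3 is therefore estimated at 8000 nM, with a range from 2500 nM to 30000 nM.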

Compound 3, half-maximal inhibitory concentration: 10100 nM
Beside the measured number, compound 3's estimate is 1.3-fold (0.10 log units) below it; the range from low to high includes it.
By their numbers in this assay, from the lowest: compounds 2, 3 and 1 (each within the scatter of the next, the first and the last beyond it).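

In this assay, among these compounds, this is the first reading at the oxygen on the aromatic ring, and the change from hydroxy to (3-methoxybenzyl)oxy is a 1.4-fold higher number from compound 2 to compound 3 (0.13 log units; within the scatter). The position therefore accepts a group of 9 heavy atoms with one six-membered aromatic ring and 0 hydrogen-bond donors in place of a hydrogen atom, with no step beyond the scatter, so in this pair neither the free hydroxy nor the added 3-methoxybenzyl separates the two compounds in this read-out. No measurement at hand offers an explanation for this reading.

Open, going by these compounds, is whether this tolerance extends to other groups on the same oxygen, such as a plain methyl, a longer alkyl chain, or a chain ending in an amine or a carboxylic acid, any of which could show a step beyond the scatter where 3-methoxybenzyl shows none. Also open, on these data alone, is whether the change reads the same with 2-bromophenyl on the saturated chain carbon bound to sulfur, since the pair at hand carries 3-methoxyphenyl there on both sides.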